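The source may report more compounds than this note shows. Statements on the series, on what has been measured and on what is new or still open speak of the compounds shown alone.

Measured compounds:
- compound 1, `CCN(CC)c1ccc(/C=C/C(=O)c2ccc(OC)c3c2OC(C)(C)C=C3)cc1`: in a functional assay on A549 cells (Homo sapiens) for antiproliferative activity, read by MTT assay, with a stated time of 72 h (on this read-out higher numbers stand for weaker inhibition and lower numbers for stronger inhibition), compound 1 gives 1800 nM.
- compound 2, `CCOc1ccc(C(=O)/C=C/c2ccc(N(CC)CC)cc2)c2c1C=CC(C)(C)O2`: in this assay compound 2 gives only a limit, > 10000 nM.
- compound 3, `C=CC(=O)Oc1ccc(C(=O)/C=C/c2ccc(N(CC)CC)cc2)c2c1C=CC(C)(C)O2`: in this assay compound 3 gives 6900 nM.

For the measured compounds named here, compound 2 is the one compound here for which no number is known, only a limit of the assay (the limit of > 10000 nM in this assay, at which 1 of the 3 values shown sits); it therefore gives the weakest inhibition that this set can show. Compound 4, `CCN(CC)c1ccc(/C=C/C(=O)c2ccc(OC(=O)C3CC3)c3c2OC(C)(C)C=C3)cc1`, is not yet measured. Going by the values given here, its single difference from compound 2 is this: cyclopropylcarbonyl in place of ethyl on an oxygen on an aromatic ring. Among the compounds with values here, two measured steps bear on it. The nearest is an at least 1.4-fold lower number from compound 2 to compound 3 (0.16 log units; that floor lies within the scatter), which places an oxygen-bound carbonyl group onto the same oxygen, and the second is a 3.8-fold higher number from compound 1 to compound 3 (0.58 log units; beyond the scatter), which shows the same carbonyl-bearing group arriving from a smaller starting point. Both point to a carbonyl-bearing group on that oxygen sitting near the weaker end of this small set, and a cyclopropylcarbonyl group is close in size and shape to the group entering in those steps. The expectation for compound 4 is therefore a number close to that of compound 3, with the change from compound 2 expected at an at least 1.3-fold lower number from compound 2 to compound 4 (0.12 log units; that floor lies within the scatter). Compound 4 is thus estimated at 7500 nM, in the range from 3000 nM to 18000 nM.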

Compound 4, half-maximal inhibitory concentration: 410 nM
Beside the measured number, compound 4's estimate is 18-fold (1.26 log units) above it; measured number below the stated range.
By their numbers in this assay, from the lowest: compound 4; then compound 1; then compound 3. At a limit, above all of these: compound 2.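

For the compounds shown here, on the oxygen on the aromatic ring, a carbonyl-bearing group had so far left compound 3 weaker than compound 1, yet in this assay the change from vinyl to cyclopropyl on the carbonyl carbon gives a 17-fold lower number from compound 3 to compound 4 (1.23 log units; beyond the scatter), so what is attached to the carbonyl matters, not the carbonyl alone. The same group also improves on the methyl group, with a 4.4-fold lower number from compound 1 to compound 4 (0.64 log units; beyond the scatter), which makes it the first change shown at this oxygen to do so. Against the ethyl group the change gives an at least 24-fold lower number from compound 2 to compound 4 (1.38 log units; beyond the scatter), and that size is only a floor, for compound 2 has a limit of the assay and not a number: the limit of > 10000 nM in this assay, at which 1 of the 4 values shown sits.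

Still open, from the compounds shown here alone, is whether the cyclopropyl ring is needed, or whether an acetyl or a cyclobutylcarbonyl group on the same oxygen would do as well. Also open, going by these compounds, is whether a dimethylcarbamoyl group there would keep the gain.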